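Amide aryl swap on a flavonol scaffold

The source may hold more compounds than are shown below. What is called first, only, known or untested is meant among the compounds shown, and "the series" means these compounds.

Compound 1 `COc1ccccc1C(=O)Nc1cccc(-c2oc3cc(-c4ccc(F)cc4)ccc3c(=O)c2O)c1`; in a functional assay on MCF7 cells (Homo sapiens) for antiproliferative activity, read by CCK-8 assay, with a stated time of 72 h (a higher number here means a weaker inhibitor, a lower number a stronger inhibitor), compound 1 gives 2100 nM.
Compound 2 `O=C(Nc1cccc(-c2oc3cc(-c4ccc(F)cc4)ccc3c(=O)c2O)c1)c1cccc(F)c1`; in this assay compound 2 gives 5770 nM.

For the measured compounds named here, compound 2 holds the higher of the two numbers measured so far, the sole step to it being a 2.7-fold higher number from compound 1 to compound 2 (0.44 log units; beyond the scatter). The next compound, compound 3 `CCc1ccc(C(=O)Nc2cccc(-c3oc4cc(-c5ccc(F)cc5)ccc4c(=O)c3O)c2)cc1`, differs from compound 2 only at the amide: 4-ethylphenyl in place of 3-fluorophenyl on a carbonyl carbon. Going by the values given here, only one measured step touches this position, and it shows that changing the aryl group on the carbonyl carbon can move the number by a modest but real amount. Neither measured compound carries the 4-ethylphenyl group, so the direction is uncertain. The step from compound 2 to compound 3 is expected to be a 1.6-fold lower number from compound 2 to compound 3 (0.22 log units; within the scatter), a small move that may lie within the scatter. Compound 3 is therefore estimated at 3500 nM, with a range from 1200 nM to 10000 nM.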

Compound 3, half-maximal inhibitory concentration: 22800 nM
For compound 3 the middle estimate is 6.5-fold (0.81 log units) below the measured one; measured number above the stated range.
By their numbers in this assay, from the lowest: compound 1; then compound 2; then compound 3.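

In this assay, for the compounds shown here, the aryl group on the carbonyl carbon proves a more sensitive point than the first pair suggested: 4-ethylphenyl in place of 3-fluorophenyl gives a 4.0-fold higher number from compound 2 to compound 3 (0.60 log units; beyond the scatter), and 4-ethylphenyl in place of 2-methoxyphenyl gives an 11-fold higher number from compound 1 to compound 3 (1.04 log units; beyond the scatter), the only large step so far. With both steps beyond the scatter, compound 3 is the weakest of the three, so an all-carbon 4-ethylphenyl group does not sit within the range set by the first two aryl groups. No supporting data bear on why this change weakens the compound.

These three aryl groups differ in both substituent and substitution pattern, so the two effects cannot be separated here. As far as these compounds go, how an unsubstituted phenyl, a 4-fluorophenyl or a 4-methoxyphenyl group would behave on the same carbonyl carbon remains open.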